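The compounds below may be only part of what the source reports. "The series", "measured", "known", "first", "only" and "open" are said of these compounds alone.

Three carbamates built on the same core have been tested in a functional assay on HT-29 cells (Homo sapiens) for cytotoxicity, read by MTT assay, with a stated time of 72 h; on this read-out lower numbers stand for higher toxicity in this test and higher numbers for lower toxicity in this test. Compound 1 `N#C[Se]c1ccc(NC(=O)OCc2ccccc2)cc1` gives 69100 nM, compound 2 `CCOC(=O)Nc1ccc([Se]C#N)cc1` gives 66600 nM, and compound 3 `N#C[Se]c1ccc(NC(=O)Oc2ccccc2)cc1` gives 71700 nM. Compound 3 carries the highest of the three numbers, yet compound 1 and compound 2 both fall within the scatter of it, so no order among the three can be read. Compound 4 `CCCCCCOC(=O)Nc1ccc([Se]C#N)cc1` differs from compound 3 by hexyl in place of phenyl on an oxygen next to a carbonyl group. Two measured steps at the same place bear on this change: a 1.0-fold lower number from compound 1 to compound 2 (0.02 log units; within the scatter) and a 1.1-fold higher number from compound 2 to compound 3 (0.03 log units; within the scatter), both within the scatter. Accordingly, no step beyond the scatter is expected in this assay. Compound 4 is therefore estimated at 70000 nM, with a range from 35000 nM to 140000 nM. This estimate corresponds to a 1.0-fold lower number from compound 3 to compound 4 (0.01 log units; within the scatter).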

Compound 4, concentration lethal to 50% of the cells: 69900 nM
For compound 4 the middle estimate is 1.0-fold (0.00 log units) above the measured one, and the stated range covers the measured number.
By their numbers in this assay, from the lowest: compounds 2, 1, 4 and 3 (each within the scatter of the next).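

In this assay, hexyl on an oxygen next to a carbonyl group takes the place of phenyl, an open chain for an aromatic ring of the same carbon count, and a 1.0-fold lower number from compound 3 to compound 4 (0.01 log units; within the scatter) shows that this exchange gives no readable difference. A longer chain gives none either: a 1.0-fold higher number from compound 2 to compound 4 (0.02 log units; within the scatter) for butyl in place of hydrogen, and a 1.0-fold higher number from compound 1 to compound 4 (0.00 log units; within the scatter) for pentyl in place of phenyl. Nothing available gives a reason for this result.

As far as these compounds go, whether a chain longer than hexyl would give a step beyond the scatter remains open. The same holds for an amine or a carboxylic acid at the end of the chain.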